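Chloro to methoxy on the pyridine ring of compound 3

The compounds below may be only part of what the source reports. "The series", "measured", "known", "first", "only" and "open" are said of these compounds alone.

The series shares a core carrying a ((4-fluorophenyl)sulfonyl)amino group on a six-membered aromatic ring with one nitrogen. Compound 1 `COc1ncc(-c2ccc3c(c2)N(c2ccc(C)cc2)C(=O)CO3)cc1NS(=O)(=O)c1ccc(F)cc1` gives 5870 nM in a functional assay on A549 cells (Homo sapiens) for antiproliferative activity, read by MTT assay, with a stated time of 72 h; on this read-out lower numbers stand for stronger inhibition and higher numbers for weaker inhibition. Compound 2 `COc1ccc(N2C(=O)COc3ccc(-c4cnc(OC)c(NS(=O)(=O)c5ccc(F)cc5)c4)cc32)cc1` gives 1350 nM in this assay, and the change from compound 1 to compound 2, methoxy in place of methyl on an aromatic carbon, gives a 4.3-fold lower number from compound 1 to compound 2 (0.64 log units; beyond the scatter). Compound 3 `O=C1COc2ccc(-c3cnc(Cl)c(NS(=O)(=O)c4ccc(F)cc4)c3)cc2N1c1ccc(F)cc1` gives 22300 nM in this assay, the highest number of the three; compound 1 is nearest to it and compound 2 furthest, both beyond the scatter.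

Compound 4 `COc1ncc(-c2ccc3c(c2)N(c2ccc(F)cc2)C(=O)CO3)cc1NS(=O)(=O)c1ccc(F)cc1` arises from compound 3 by the change (methoxy in place of chloro on an aromatic carbon). Among the compounds with values here, no measured step covers this change directly; the only measured step, from compound 1 to compound 2, concerns a different place and a different pair of groups. What the data do show is that compound 1 and compound 2, which both carry methoxy at this position of the core, give lower numbers than compound 3, which carries chloro there. Compound 4 is therefore expected to give a lower number than compound 3, the step being estimated at a 4.5-fold lower number from compound 3 to compound 4 (0.65 log units; beyond the scatter). In this assay compound 4 is estimated at 5000 nM, within a range from 1500 nM to 16000 nM.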

Compound 4, half-maximal inhibitory concentration: 6500 nM
For compound 4 the middle estimate is 1.3-fold (0.11 log units) below the measured one; low and high end bracket the measured number.
By their numbers in this assay, from the lowest: compound 2; then compounds 1 and 4 (each within the scatter of the next); then compound 3.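

In this assay, within the data shown here, methoxy in place of chloro on the aromatic carbon next to the ring nitrogen, ortho to a ((4-fluorophenyl)sulfonyl)amino group, gives a 3.4-fold lower number from compound 3 to compound 4 (0.54 log units; beyond the scatter) with nothing else in the structure altered, a direct reading that the earlier compounds, each differing from compound 3 in two places, could not give. Compound 4 also adds fluoro to the series at the second place of variation, where fluoro in place of methoxy gives a 4.8-fold higher number from compound 2 to compound 4 (0.68 log units; beyond the scatter) and fluoro in place of methyl gives a 1.1-fold higher number from compound 1 to compound 4 (0.04 log units; within the scatter) in the same assay. Of the three groups shown at that place, only the methoxy of compound 2 separates from the others by more than the scatter.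

With a single matched pair, the compounds shown leave open whether the chloro-to-methoxy step keeps its size when methyl or methoxy occupies the second place. They also leave open how other groups on the same carbon, such as an amine, an ethoxy chain or a plain hydrogen, would compare with chloro and methoxy. No measurement offered here explains either step.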